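This account rests on a few compounds, and the source may have more. Where it says the series, first, only, none or still open, it means among the compounds named here.

Three compounds have been measured in a functional assay on HeLa cells (Homo sapiens) for antiproliferative activity, read by sulforhodamine B assay, with a stated time of 48 h; a lower number here means a stronger inhibitor, a higher number a weaker inhibitor:

compound 1, `COc1ccc(C[C@@H](O)/C=C/C=C/C(=O)NCc2ccccc2)cc1OC`, gives 12900 nM
compound 2, `COc1ccc(CNC(=O)/C=C/C=C/[C@H](O)Cc2ccc(OC)c(OC)c2)cc1`, gives 9450 nM
compound 3, `COc1ccc(C[C@@H](O)/C=C/C=C/C(=O)N2CCN(c3ccccn3)CC2)cc1OC`, gives 23600 nM

Compound 3 shows the highest number of the three. Its gap to compound 1 lies within the scatter, so no order between those two can be read from the data; its gap to compound 2 lies beyond the scatter.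

Compound 4, `CCN1CCN(C(=O)/C=C/C=C/[C@H](O)Cc2ccc(OC)c(OC)c2)CC1`, is compound 3 with one change: ethyl in place of pyridin-2-yl on an amine nitrogen in a ring. Among the measured compounds shown here, the single measured step, a 1.4-fold lower number from compound 1 to compound 2 (0.14 log units; within the scatter), concerns a methoxy on an aromatic ring, a different part of the molecule, so it does not bear on the change in compound 4. Compounds 1 and 3 differ in the amide part as well, and their two numbers lie within the scatter of each other. With nothing measured that speaks to swapping a group on this ring nitrogen, the expected step is a 1.1-fold higher number from compound 3 to compound 4 (0.03 log units; within the scatter), that is, no change beyond the scatter, but with wide uncertainty. Compound 4 is therefore expected at 25000 nM, between 9000 nM and 70000 nM.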

Compound 4, half-maximal inhibitory concentration: 11700 nM
Beside the measured number, compound 4's estimate is 2.1-fold (0.33 log units) above it, and the stated range covers the measured number.
By their numbers in this assay, from the lowest: compounds 2, 4, 1 and 3 (each within the scatter of the next, the first and the last beyond it).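

In this assay, the step on this amine nitrogen in a ring (a 2.0-fold lower number from compound 3 to compound 4 (0.30 log units; within the scatter)) lies within the scatter, so ethyl, with no ring, and pyridin-2-yl, with its aromatic ring, cannot be told apart here. The same holds for a larger exchange on the carbonyl carbon, 4-ethylpiperazin-1-yl in place of benzylamino (a 1.1-fold lower number from compound 1 to compound 4 (0.04 log units; within the scatter)), so the data show no clear effect of either change on antiproliferative activity. No measured evidence offers an explanation for these results.

The compounds shown leave open whether this ring nitrogen would tolerate a group of a different kind, such as a carboxylic acid on a short chain, an acetyl group or a longer alkyl chain. They also leave open whether a hydrogen on this nitrogen would give a step beyond the scatter.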